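Three methoxy groups on the pendant phenyl of compound 4

The source may report more compounds than this note shows. Statements on the series, on what has been measured and on what is new or still open speak of the compounds shown alone.

Compound 1 `COc1cc(/C=C/C(=O)c2cccc(-n3cc(-c4ccc(Cl)cc4)[nH]c3=O)c2)cc(OC)c1OC`: 18100 nM in a functional assay on Malme-3M cells (Homo sapiens) for inhibition; on this read-out lower numbers stand for stronger inhibition of growth and higher numbers for weaker inhibition of growth
Compound 2 `COc1cc(/C=C/C(=O)c2cccc(-n3cc(-c4ccccc4)[nH]c3=O)c2)cc(OC)c1OC`: 1310 nM
Compound 3 `COc1ccc(-c2cn(-c3cccc(C(=O)/C=C/c4cc(OC)c(OC)c(OC)c4)c3)c(=O)[nH]2)cc1`: 1790 nM

Compound 3 stands second highest of the three numbers in this assay; its nearest neighbour is reached by a 1.4-fold higher number from compound 2 to compound 3 (0.14 log units; within the scatter), and the furthest by a 10-fold lower number from compound 1 to compound 3 (1.00 log units; beyond the scatter). Compound 4 `COc1cc(/C=C/C(=O)c2cccc(-n3cc(-c4cc(OC)c(OC)c(OC)c4)[nH]c3=O)c2)cc(OC)c1OC` differs from compound 3 by 3,4,5-trimethoxyphenyl in place of 4-methoxyphenyl on an aromatic carbon. The measured steps at this position are a 14-fold lower number from compound 1 to compound 2 (1.14 log units; beyond the scatter) and a 10-fold lower number from compound 1 to compound 3 (1.00 log units; beyond the scatter), both sizeable, whereas a 1.4-fold higher number from compound 2 to compound 3 (0.14 log units; within the scatter). That last step, methoxy in place of hydrogen, bears most directly on the present change, which again brings methoxy groups onto the same ring. Compound 4 is therefore expected to show only a 1.1-fold higher number from compound 3 to compound 4 (0.05 log units; within the scatter). The estimate for compound 4 in this assay is 2000 nM, with a range from 700 nM to 6000 nM.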

Compound 4, concentration for 50% growth inhibition: 1800 nM
For compound 4 the middle estimate is 1.1-fold (0.05 log units) above the measured one; low and high end bracket the measured number.
By their numbers in this assay, from the lowest: compounds 2, 3 and 4 (each within the scatter of the next); then compound 1.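

In this assay the phenyl ring on the shared core carries three methoxy groups as readily as one or none: 3,4,5-trimethoxyphenyl in place of 4-methoxyphenyl gives a 1.0-fold higher number from compound 3 to compound 4 (0.00 log units; within the scatter), and in place of phenyl it gives a 1.4-fold higher number from compound 2 to compound 4 (0.14 log units; within the scatter). In place of 4-chlorophenyl it gives a 10-fold lower number from compound 1 to compound 4 (1.00 log units; beyond the scatter), so among these four compounds only compound 1 stands apart. Nothing measured here explains this pattern. From the compounds shown here alone, whether an amine or a carboxylic acid on this ring would fit the same pattern remains open.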